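Notes on tert-butyl versus isobutyl in the chromone series

The compounds below may be only part of what the source reports. "The series", "measured", "known", "first", "only" and "open" are said of these compounds alone.

Compound 1 `CC(C)(C)c1cc(=O)c2ccc(O)cc2o1` gives > 100000 nM in an assay on isolated protein for inhibition of Polyunsaturated fatty acid lipoxygenase ALOX12 (Homo sapiens) (a lower number here means a stronger inhibitor, a higher number a weaker inhibitor), which is a limit of the assay and not a number. Compound 2 `CCCCCc1cc(=O)c2ccc(O)cc2o1` gives > 100000 nM in this assay, again a limit. Compound 3 `CC(C)Cc1oc2ccccc2c(=O)c1O` gives > 100000 nM in this assay, also a limit. For the measured compounds named here, the only measured step, a step that the two limits leave unreadable from compound 1 to compound 2, is therefore unreadable in size and direction, and the limit of > 100000 nM in this assay, at which 3 of the 3 values shown sit, is the whole of the evidence: every value shown sits at that limit, so compound 3 stands with compounds 1 and 2 at the limit, with no ordering possible among them.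

Compound 4 `CC(C)(C)c1oc2ccccc2c(=O)c1O` is not yet measured in this assay. The change from compound 3 is tert-butyl in place of isobutyl on an aromatic carbon; the two compounds have the same atoms joined differently. Going by the values given here, no measured step bears on this change, since the step from compound 1 to compound 2 is unreadable. With every value at the limit, no movement beyond the scatter can be expected from a rearrangement of four carbons; the expected step that the limit leaves unreadable from compound 3 to compound 4 is none. Compound 4 is therefore estimated at 200000 nM, with a range from 80000 nM to 1000000 nM, and is expected most likely to return a limit rather than a number.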

Compound 4, half-maximal inhibitory concentration: > 100000 nM
Compound 4: no number, only a limit; the forecaster's own chance of this, stated with the estimate: 90%; the middle value lies beyond the limit too.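

For the compounds shown here, compound 3 and compound 4 both return only a limit, so no step between them can be read in size or direction, and the same holds for every pair: the limit of > 100000 nM in this assay, at which 4 of the 4 values shown sit. The compounds shown leave open what order, if any, holds among them in this assay and whether any group on these cores gives a readable inhibition there.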